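Adding a Hydroxy Group to the Phenyl Ring of Compound 1

The source may report more compounds than this note shows. Statements on the series, on what has been measured and on what is new or still open speak of the compounds shown alone.

Measured compounds:
compound 1, `O=C1N=C(C2C(=O)c3ccccc3C2=O)CC(c2ccccc2)N1`: 21%
compound 2, `O=C1N=C(C2C(=O)c3ccccc3C2=O)CC(c2cccc([N+](=O)[O-])c2)N1`: 21%

In a functional assay on the whole organism for inhibition, with Rattus norvegicus as the target, read by paw edema, with stated times of 30 min and 3 h, at a dose of 10 mg/kg by the oral route (a higher number here means more inhibition at the dose given (going by the name of the read-out), a lower number less inhibition), compound 1 gives 21% and compound 2 gives 21%. Compound 1 therefore stands level with compound 2 at the digits shown, and compound 2 is its only measured neighbour. Among the measured compounds shown here, the one measured step, no change at the digits printed from compound 1 to compound 2 (within the scatter), introduces a nitro group and stays within the scatter.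

Compound 3, `O=C1N=C(C2C(=O)c3ccccc3C2=O)CC(c2ccccc2O)N1`, differs from compound 1 by hydroxy in place of hydrogen on an aromatic carbon, the hydroxy sitting ortho to a large group. For the measured compounds named here, only that single nitro step bears on this change, and it concerns another group at another site, so it is a loose guide. Since it showed no movement, the expected step is none beyond the scatter, a number 1 percentage points higher from compound 1 to compound 3 (within the scatter). Compound 3 is estimated to give 22%, with a range from 10% to 38%.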

Compound 3, a percentage reported as inhibition, in the whole organism at one dose (the size of the read-out at that dose, not a potency): 19%
For compound 3 the middle estimate is 3 percentage points above the measured one; the measured number falls inside the stated range.
By their numbers in this assay, from the lowest: compounds 3, 1 and 2 (each within the scatter of the next).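

In this assay the change from phenyl to 2-hydroxyphenyl gives a number 2 percentage points lower from compound 1 to compound 3 (within the scatter) and so shows that this place on the aromatic ring, ortho to a large group, takes a hydroxy group, with its hydrogen-bond donor, without a shift beyond the scatter. Replacing the 3-nitrophenyl group gives a number 2 percentage points lower from compound 2 to compound 3 (within the scatter) and so a second kind of group, at a different place on the ring, also leaves the read-out within the scatter. Nothing measured here explains why these changes leave the inhibition within the scatter.

On these data alone, whether an amine or a carboxylic acid on the same ring, or a methoxy group in place of the hydroxy, would move the number beyond the scatter stays open. Also open, as far as these compounds go, is whether changes to the shared core would do so.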